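This account rests on a few compounds, and the source may have more. Where it says the series, first, only, none or still open, it means among the compounds named here.

Three compounds have been measured in an ADME assay, at pH 5 (on this read-out higher numbers stand for a longer-lived compound and lower numbers for a shorter-lived compound), so far:

Compound 1, `COc1cc2[nH]c([S+]([O-])Cc3nccc(OC)c3OC)nc2cc1OC(F)F`, gives 2.1 h.
Compound 2, `COc1cc2[nH]c([S+]([O-])Cc3nccc(OC)c3C)nc2cc1OC(F)F`, gives 0.2 h.
Compound 3, `COc1ccnc(C[S+]([O-])c2nc3cc(F)c(OC(F)F)cc3[nH]2)c1OC`, gives 8.3 h.

Compound 1 and compound 2 share one core and differ in a single place: methyl in place of methoxy on an aromatic carbon. In this assay this change produced an 11-fold lower number from compound 1 to compound 2 (1.02 log units; beyond the scatter), a step well beyond the usual scatter of the measurement. Compound 3 carries a different core, and how that core differs from the core of compound 1 is not broken down here; what the numbers show is that compound 3 has the highest value of the three in this assay.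

Compound 4, `COc1ccnc(C[S+]([O-])c2nc3cc(F)c(OC(F)F)cc3[nH]2)c1C`, has not yet been measured. It is built from compound 3 by the change (methyl in place of methoxy on an aromatic carbon). The place of this change is described in exactly the same words as for the step from compound 1 to compound 2, so the two steps are the same change made on two different cores. Within the data shown here, the only guide to its size is the measured pair, where it gave an 11-fold lower number from compound 1 to compound 2 (1.02 log units; beyond the scatter), and the expectation for compound 4 rests on that single step because of an 11-fold lower number from compound 1 to compound 2 (1.02 log units; beyond the scatter) and the value of compound 3, 8.3 h. For compound 4 the expected step is an 11-fold lower number from compound 3 to compound 4 (1.04 log units; beyond the scatter). Compound 4 is therefore estimated at 0.75 h in this assay, with a likely range from 0.3 h to 2 h.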

Compound 4, half-life: 0.5 h
Compound 4: middle estimate off by 1.5-fold (0.18 log units), on the high side; the measured number falls inside the stated range.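

In this assay, putting methyl in place of methoxy on an aromatic carbon again lowered the number, giving a 17-fold lower number from compound 3 to compound 4 (1.22 log units; beyond the scatter), a large step on the core that compound 3 carries. Set beside the earlier pair, the change moved the number the same way on both cores, and the two steps cannot be told apart: the same change on two cores in this assay, an 11-fold lower number (1.02 log units; beyond the scatter) from compound 1 to compound 2 and a 17-fold lower number (1.22 log units; beyond the scatter) from compound 3 to compound 4, 1.6-fold (0.20 log units) apart, within the scatter of two such steps This shows that, across these two cores, the step from methoxy to methyl carried over in direction and in size, so the earlier pair was a fair guide to the later one, but it rests on only two pairs in a single assay and does not show that the step would hold on any other core, nor does it say why the number falls.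

The compounds shown leave open what another group in the same place, such as an ethyl group, a chlorine atom or an amine, would give on either core. They also leave open whether the same step would appear on a core carrying something other than the fluorine of compound 3 or the methoxy of compound 1.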